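This account rests on a few compounds, and the source may have more. Where it says the series, first, only, none or still open, it means among the compounds named here.

In a functional assay on Hs 683 cells (Homo sapiens) for inhibition, read by colorimetric assay and MTT assay, with a stated time of 72 h (a higher number here means a weaker inhibitor, a lower number a stronger inhibitor), compound 1 `C/C1=C\CC[C@@]2(C)O[C@@H]2[C@H]2OC(=O)[C@@H](CN3CCN(C)CC3)[C@@H]2C[C@H]1O` gives 33000 nM, compound 2 `C/C1=C\CC[C@@]2(C)O[C@@H]2[C@H]2OC(=O)[C@@H](CN3CCN(c4ccccc4)CC3)[C@@H]2C[C@H]1O` gives 22000 nM and compound 3 `C/C1=C\CC[C@@]2(C)O[C@@H]2[C@H]2OC(=O)[C@@H](CN3CCN(c4ccccc4F)CC3)[C@@H]2C[C@H]1O` gives 25000 nM. Compound 3 therefore lies within the scatter of both others, and the three cannot be ranked. Compound 4 `COc1ccc(N2CCN(C[C@@H]3C(=O)O[C@H]4[C@H]3C[C@@H](O)/C(C)=C/CC[C@@]3(C)O[C@H]43)CC2)cc1` keeps the shared core but has 4-methoxyphenyl in place of 2-fluorophenyl on an amine nitrogen in a ring. Changing the group on that nitrogen gave a 1.5-fold lower number from compound 1 to compound 2 (0.18 log units; within the scatter) and a 1.3-fold lower number from compound 1 to compound 3 (0.12 log units; within the scatter), while fluoro in place of hydrogen on an aromatic carbon gave a 1.1-fold higher number from compound 2 to compound 3 (0.06 log units; within the scatter). For the measured compounds named here, no measured compound carries a methoxy group, so these small steps are the only guide, and no step beyond the scatter is expected in this assay. The expected step is a 1.1-fold lower number from compound 3 to compound 4 (0.04 log units; within the scatter). For compound 4 the estimated value is 23000 nM, with a range of 11000 nM to 45000 nM.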

Compound 4, half-maximal inhibitory concentration: 22000 nM
Compound 4: middle estimate off by 1.0-fold (0.02 log units), on the high side, and the stated range covers the measured number.
By their numbers in this assay, from the lowest: compounds 2, 4, 3 and 1 (each within the scatter of the next).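

In this assay, 4-methoxyphenyl in place of 2-fluorophenyl on an amine nitrogen in a ring gives a 1.1-fold lower number from compound 3 to compound 4 (0.06 log units; within the scatter) and 4-methoxyphenyl in place of phenyl gives no change at the digits printed from compound 2 to compound 4 (within the scatter), while 4-methoxyphenyl in place of methyl gives a 1.5-fold lower number from compound 1 to compound 4 (0.18 log units; within the scatter) at the same nitrogen. For the compounds shown here, this position has now carried a methoxy-bearing phenyl as well, and no step to it leaves the scatter. No evidence on the reason is available. On these data alone, whether an amine or carboxylic acid on the phenyl ring, or a longer chain on that nitrogen, would shift the number remains open.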